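From Cyclopropylmethyl to Cyclobutyl on the Amine Nitrogen

The source may report more compounds than this note shows. Statements on the series, on what has been measured and on what is new or still open speak of the compounds shown alone.

Compound 1 `c1nc(N2CCCCC2)c2ncn(CC3CC3)c2n1` and compound 2 `c1nc(NCC2CC2)c2ncn(CC3CC3)c2n1` share one core and differ only in the group carried on an aromatic carbon. In a functional assay on the whole organism for inhibition, with Rattus norvegicus as the target, at a dose of 25 mg/kg by the intraperitoneal route (a lower number here means less inhibition, a higher number more inhibition at the dose given (going by the name of the read-out)), compound 1 gives 28%, and compound 2 gives 28% in the same assay; the step of no change at the digits printed from compound 1 to compound 2 (within the scatter) shows no change within the scatter. Within the data shown here, compound 2 therefore stands level with compound 1 on the only numbers in hand. Compound 3 `c1nc(NC2CCC2)c2ncn(CC3CC3)c2n1` follows from compound 2 by the change (cyclobutyl in place of cyclopropylmethyl on a nitrogen on an aromatic ring). Among the measured compounds shown here, no measured step concerns this kind of exchange; the one step known, from compound 1 to compound 2, concerns a different replacement and was flat. With nothing pointing either way, the step of no change at the digits printed from compound 2 to compound 3 (within the scatter) is expected to stay within the scatter, with a wide margin of doubt. Compound 3 is accordingly estimated to give 28% in this assay, with a range from 8% to 50%.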

Compound 3, a percentage reported as inhibition, in the whole organism at one dose (the size of the read-out at that dose, not a potency): 0%
The estimate for compound 3 lay 28 percentage points above the measured number; the whole stated range lies above it.
By their numbers in this assay, from the lowest: compound 3; then compounds 1 and 2 (each within the scatter of the next).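

Among these compounds, the change matters more than the earlier compounds suggested: with the same atoms joined differently, the step of a number 28 percentage points lower from compound 2 to compound 3 (beyond the scatter) in this assay shows that this position does not treat cyclopropylmethyl and cyclobutyl alike. The step of a number 28 percentage points lower from compound 1 to compound 3 (beyond the scatter) shows the same for cyclobutylamino in place of piperidin-1-yl on an aromatic carbon, so the level reading of the first two compounds does not extend to every group tried here. Nothing measured on these compounds accounts for the difference.

The compounds shown leave open whether the number depends on the ring sitting directly on the nitrogen or on the size of that ring. A cyclopentyl or cyclopropyl group there, or an open chain such as n-butyl, could tell these readings apart.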